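The source may hold more compounds than are shown below. What is called first, only, known or untested is meant among the compounds shown, and "the series" means these compounds.

Measured compounds:
- compound 1 `O=C(O)c1cc(-c2cccc(COc3ccc4c(c3)CN(CC3CC3)C4=O)c2)ccc1Cl`: 100%
- compound 2 `O=C(O)c1cc(-c2cccc(COc3ccc4c(c3)CN(Cc3ccc(C(F)(F)F)cc3)C4=O)c2)ccc1Cl`: 100%
- compound 3 `CC(C)CCN1Cc2cc(OCc3cccc(-c4ccc(Cl)c(C(=O)O)c4)c3)ccc2C1=O`: 94%

In an ADME assay on a cell-free system (plasma, Rattus norvegicus), with a stated time of 60 min (a higher number here means that more of the compound is left, a lower number that less of the compound is left), compound 3 gives 94%, which lies within the scatter of both other compounds: the data show a number 6 percentage points lower from compound 1 to compound 3 (within the scatter) and a number 6 percentage points lower from compound 2 to compound 3 (within the scatter). The next compound, compound 4 `O=C(O)c1cc(-c2cccc(COc3ccc4c(c3)CN(C3CCCCC3)C4=O)c2)ccc1Cl`, changes the same part of the molecule: cyclohexyl in place of isopentyl on an amide-type nitrogen in a ring.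

Within the data shown here, three measured steps bear on this change. Besides the two above, there is no change at the digits printed from compound 1 to compound 2 (within the scatter). Each swaps the group on that nitrogen's side of the molecule, and none goes beyond the scatter. Among the measured compounds shown here, still, compound 1 and compound 2 carry their rings on a saturated chain carbon bound to the nitrogen, so no measured compound has a ring placed as in compound 4. That leaves some uncertainty, but no step beyond the scatter is expected in this assay. The expected step is a number 3 percentage points higher from compound 3 to compound 4 (within the scatter). Compound 4 is expected at 97%, with an estimated range of 85% to 100%.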

Compound 4, percent of the compound remaining: 99%
For compound 4 the middle estimate is 2 percentage points below the measured one, within the range that was stated.
By their numbers in this assay, from the lowest: compounds 3, 4, 1 and 2 (each within the scatter of the next).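

In this assay, among these compounds, cyclohexyl is the first ring placed directly on the amide-type nitrogen, and the data give a number 5 percentage points higher from compound 3 to compound 4 (within the scatter) and a number 1 percentage points lower from compound 2 to compound 4 (within the scatter) and also a number 1 percentage points lower from compound 1 to compound 4 (within the scatter) for this change. Moving a ring from a chain carbon onto the nitrogen itself therefore gives no step beyond the scatter, and among these four compounds none goes against this, whether the group is isopentyl, cyclopropylmethyl, 4-(trifluoromethyl)benzyl or cyclohexyl. No supporting measurement is available to explain this result.

From the compounds shown here alone, all four groups on the nitrogen are free of an amine or an ester, so it remains open whether either of these at this position would leave the number within the scatter. Going by these compounds, the carboxylic acid is also shared by all four compounds, so what an ester in its place would do remains open too.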